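Compound 3: one more chain carbon at a limit

The source may report more compounds than this note shows. Statements on the series, on what has been measured and on what is new or still open speak of the compounds shown alone.

Measured in an ADME assay on Raji cells (Homo sapiens) for cytotoxicity, read by luminescence, with a stated time of 72 h; on this read-out lower numbers stand for an effect already at smaller amounts and higher numbers for an effect only at larger amounts of compound:
- Compound 1 `CCOC(=O)c1c(-c2cccc(Oc3ccccc3)c2)[nH]c2cc(OC)c(F)cc2c1=O` gives > 21500 nM, a limit.
- Compound 2 `COc1cc2[nH]c(-c3cccc(Oc4ccccc4)c3)c(C(=O)NCCN3CCCC3)c(=O)c2cc1F` gives > 21500 nM, a limit.

Compound 2 gives only a limit, > 21500 nM. Among the compounds with values here, the series so far rests on (the limit of > 21500 nM in this assay, at which 2 of the 2 values shown sit).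

The next compound is compound 3 `COc1cc2[nH]c(-c3cccc(Oc4ccccc4)c3)c(C(=O)NCCCN3CCCC3)c(=O)c2cc1F`, with this change from compound 2: (pyrrolidin-1-yl)methyl in place of pyrrolidin-1-yl on a saturated chain carbon, two bonds along the chain from an amide-type nitrogen. The same difference reads 2-(pyrrolidin-1-yl)ethyl to 3-(pyrrolidin-1-yl)propyl.

Within the data shown here, the one measured step, a step that the two limits leave unreadable from compound 1 to compound 2, changes a different group and gives no size to carry over. No step beyond the scatter is therefore expected in this assay, and no direction can be expected, so another limit is the likeliest report. The expected change is a number no higher from compound 2 to compound 3 (the limit leaves the size open). For compound 3 the estimated value is 21500 nM, with an expected range of 8000 nM to 35000 nM.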

Compound 3, half-maximal effective concentration: > 21500 nM
Compound 3: only a limit was reported (the forecaster's own chance of this, stated with the estimate: 75%); the middle value lies on the limit itself.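

Compound 1, compound 2 and compound 3 all sit at the same limit in this assay, so none of the steps among them can be read: the limit of > 21500 nM in this assay, at which 3 of the 3 values shown sit.

The compounds shown leave open whether replacing ethoxy or lengthening the chain to 3-(pyrrolidin-1-yl)propyl changes the effect at all.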